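From 4-ethylphenyl to 3-methoxyphenyl on the amide-type nitrogen

The compounds below may be only part of what the source reports. "The series", "measured", "known", "first", "only" and "open" are said of these compounds alone.

In a physicochemical assay for lipophilicity, read by mass spectrometry (a lower number here means a more polar compound, a higher number a more lipophilic compound), compound 1 (`COc1cc2c(cc1OC)C(=O)C(C(=O)Nc1ccccc1)C2`) gives 2.2 as the reference point, compound 2 (`CCc1ccc(NC(=O)C2Cc3cc(OC)c(OC)cc3C2=O)cc1`) gives 3.11 and compound 3 (`COc1cc2c(cc1OC)C(=O)C(C(=O)Nc1ccc(Br)cc1)C2`) gives 3.03 on the same scale. The last two values cannot be separated (a number 0.08 log units lower from compound 2 to compound 3 (within the scatter)). Compound 2 therefore sits in the upper pair of the three, level with compound 3 and clear of compound 1.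

The next structure is compound 4 (`COc1cccc(NC(=O)C2Cc3cc(OC)c(OC)cc3C2=O)c1`), reached from compound 2 by a single change (3-methoxyphenyl in place of 4-ethylphenyl on an amide-type nitrogen), with 3-methoxyphenyl in place of 4-ethylphenyl on an amide-type nitrogen.

Going by the values given here, two measured steps bear on this. Ethyl in place of hydrogen on an aromatic carbon gave a modest move beyond the scatter (a number 0.91 log units higher from compound 1 to compound 2 (beyond the scatter)), and bromo in the same role gave one of similar size (a number 0.83 log units higher from compound 1 to compound 3 (beyond the scatter)). Compound 4 has no ethyl, so most of the first step is expected to be given back. Among the compounds with values here, no measured step covers a methoxy group, which leaves that part open and the range wide. The expected step is downward and beyond the scatter (a number 0.71 log units lower from compound 2 to compound 4 (beyond the scatter)). Compound 4 is estimated at 2.4 in this assay, with an expected range from 2.05 to 2.8 on this scale.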

Compound 4, partition coefficient: 2.08
The estimate for compound 4 lay 0.32 log units above the measured number; the range from low to high includes it.
By their numbers in this assay, from the lowest: compounds 4 and 1 (each within the scatter of the next); then compounds 3 and 2 (each within the scatter of the next).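

In this assay, going by these compounds alone, 3-methoxyphenyl is the first substituted ring on the amide-type nitrogen that cannot be separated from the unsubstituted phenyl of the reference compound, with a number 0.12 log units lower from compound 1 to compound 4 (within the scatter). A substituent on this ring therefore does not by itself carry the number away from that of compound 1, as the ethyl of compound 2 and the bromo of compound 3 might have suggested; compound 4 goes against any such reading, and the exchanges of the substituted rings show the gap directly, with a number 1.03 log units lower from compound 2 to compound 4 (beyond the scatter) and a number 0.95 log units lower from compound 3 to compound 4 (beyond the scatter). Nothing measured on these compounds accounts for the difference between methoxy and the other two groups.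

Since 3-methoxyphenyl differs from both 4-ethylphenyl and 4-bromophenyl in the group as well as in the number of its ring position, these compounds cannot separate the effect of the group from the effect of where it stands. Also open, on these data alone, is whether an amine or a carboxylic acid on this ring would stay level with compound 1, as methoxy does, or move beyond the scatter, as ethyl and bromo do.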